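The source may hold more compounds than are shown below. What is called first, only, known or untested is meant among the compounds shown, and "the series" means these compounds.

Measured so far in a functional assay on Jurkat cells (Homo sapiens) for antiproliferative activity, read by MTT assay, with a stated time of 72 h (a higher number here means a weaker inhibitor, a lower number a stronger inhibitor), are these values:
- compound 1 `COc1cc(C(=O)c2sc3ccccc3c2-c2ccc(C)cc2)cc(OC)c1OC` at 3300 nM
- compound 2 `COc1ccc(-c2c(C(=O)c3cc(OC)c(OC)c(OC)c3)sc3ccccc23)cc1` at 1600 nM
- compound 3 `COc1cc(C(=O)c2sc3ccccc3c2Nc2ccccc2)cc(OC)c1OC` at 1600 nM

Compound 3 stands level with compound 2 at the digits shown, and the two share the lowest number of the three (a 2.1-fold lower number from compound 1 to compound 3 (0.31 log units; beyond the scatter)). Compound 4 `CCOc1ccc(Nc2c(C(=O)c3cc(OC)c(OC)c(OC)c3)sc3ccccc23)cc1` adds ethoxy in place of hydrogen on an aromatic carbon with ethoxy in place of hydrogen on an aromatic carbon, para to a large group. Going by the values given here, no measured compound carries a substituted anilino, so the guidance is indirect. The closest guide is methoxy in place of methyl (a 2.1-fold lower number from compound 1 to compound 2 (0.31 log units; beyond the scatter)), a modest step. The swap of anilino for 4-methoxyphenyl (no change at the digits printed from compound 2 to compound 3 (within the scatter)) adds no size. A modest move to a lower number is therefore expected (a 2.1-fold lower number from compound 3 to compound 4 (0.33 log units; beyond the scatter)). In this assay compound 4 is estimated at 750 nM (expected range 180 nM to 2800 nM).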

Compound 4, half-maximal inhibitory concentration: 300 nM
Compound 4: the middle estimate sits 2.5-fold (0.40 log units) above what was measured; the measured number falls inside the stated range.
By their numbers in this assay, from the lowest: compound 4; then compounds 2 and 3 (each within the scatter of the next); then compound 1.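

In this assay, ethoxy on the anilino phenyl ring, para to a large group, gives a 5.3-fold lower number from compound 3 to compound 4 (0.73 log units; beyond the scatter) and exceeds each earlier step in size. Anilino alone stood level with 4-methoxyphenyl, yet (4-ethoxyphenyl)amino gives a 5.3-fold lower number from compound 2 to compound 4 (0.73 log units; beyond the scatter) and, in place of 4-methylphenyl, an 11-fold lower number from compound 1 to compound 4 (1.04 log units; beyond the scatter) at this position. No measured evidence accounts for this gain.

The compounds shown leave open whether the gain is specific to ethoxy, as against methoxy or propoxy at the same place. Also open, on these data alone, is whether 4-ethoxyphenyl without the amino link would give a similar step.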